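Methyl on the ring carbon, carried to a second core

This account rests on a few compounds, and the source may have more. Where it says the series, first, only, none or still open, it means among the compounds named here.

Of the compounds shown here, three have been measured in an assay on the whole organism (plasma, strain Sprague-Dawley) for inhibition of Dipeptidyl peptidase 4 (Rattus norvegicus), with a stated time of 10 h, at a dose of 1 mg/kg by the oral route; a higher number here means more inhibition at the dose given (going by the name of the read-out), a lower number less inhibition. Compound 1 `CCN(C)C(=O)[C@H]1C[C@@H](C(=O)N2CCC[C@H]2C#N)N[C@H]1C` gives 79% in this assay. Compound 2 `N#C[C@@H]1CCCN1C(=O)[C@@H]1C[C@H](C(=O)N2CCCCC2)CN1` gives 50% in this assay, and compound 3 `CCN(C)C(=O)[C@@H]1CN[C@H](C(=O)N2CCC[C@H]2C#N)C1` gives 34% in this assay.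

Compound 3 and compound 1 differ in one place: methyl in place of hydrogen on a saturated ring carbon. The measured step for this change is a number 45 percentage points higher from compound 3 to compound 1 (beyond the scatter). Compound 3 and compound 2 differ at the carbonyl carbon: piperidin-1-yl in place of ethyl(methyl)amino on a carbonyl carbon, with a step of a number 16 percentage points lower from compound 2 to compound 3 (beyond the scatter).

Compound 4 `C[C@@H]1N[C@H](C(=O)N2CCC[C@H]2C#N)C[C@@H]1C(=O)N1CCCCC1` has not yet been measured in this assay. It stands to compound 2 as compound 1 stands to compound 3: methyl in place of hydrogen on a saturated ring carbon. The surroundings of the place are not identical, since in compound 2 the ring atom bears a group of 8 heavy atoms where in compound 3 it bears an ethyl(methyl)carbamoyl group (6 heavy atoms); the change is therefore the same kind of change, not the same.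

For compound 4 in this assay a step of a number 30 percentage points higher from compound 2 to compound 4 (beyond the scatter) is expected, smaller than the earlier one because compound 2 already starts from 50% and the read-out is bounded. Compound 4 is estimated at 80%, expected to lie between 60% and 95%.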

Compound 4, a percentage reported as inhibition, in the whole organism at one dose (the size of the read-out at that dose, not a potency): 81%
Estimate against measurement, compound 4: 1 percentage points below; low and high end bracket the measured number.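

In this assay, methyl in place of hydrogen on a saturated ring carbon carries to the second core, giving a number 31 percentage points higher from compound 2 to compound 4 (beyond the scatter), and the two steps for this change agree: the same change on two cores in this assay, a number 45 percentage points higher (beyond the scatter) from compound 3 to compound 1 and a number 31 percentage points higher (beyond the scatter) from compound 2 to compound 4, 14 percentage points apart, within the scatter of two such steps Piperidin-1-yl in place of ethyl(methyl)amino on a carbonyl carbon gives a number 2 percentage points higher from compound 1 to compound 4 (within the scatter) on the core bearing the methyl, and this step also agrees with its counterpart on the core without the methyl: the same change on two cores in this assay, a number 16 percentage points lower (beyond the scatter) from compound 2 to compound 3 and a number 2 percentage points lower (within the scatter) from compound 4 to compound 1, 14 percentage points apart, within the scatter of two such steps The transfer is shown only for these two carbonyl substituents, at one dose and one stated time, and these numbers give no reason for the gain and no rule for other cores.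

From the compounds shown here alone, whether ethyl in place of the methyl on that ring carbon keeps a step of this size remains open. Also open, going by these compounds, is whether the methyl step holds when morpholin-4-yl or a primary amine stands in place of piperidin-1-yl on the carbonyl carbon.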